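Series notes: indole carboxamide piperidines at the serotonin receptor

A few compounds are considered here, and "the series" means these few. Any claim that something is new, unique, unknown or untested is made for them only; others in the source may bear on it.

Of the compounds shown here, two carry a number so far. Compound 1 `CS(=O)(=O)N1CCN(CC(O)CN2CCC(NC(=O)c3cccc4[nH]cnc34)CC2)CC1` gives 251 nM in an assay on isolated protein for binding affinity to 5-hydroxytryptamine receptor 4 (Homo sapiens); a higher number here means a weaker inhibitor, a lower number a stronger inhibitor. Compound 2 `CC(C)c1nc2c(C(=O)NCC3CCN(CCN4CCN(S(C)(=O)=O)CC4)CC3)cccc2[nH]1` gives 0.794 nM in this assay. Compound 2 holds the lower of the two numbers, and the gap to compound 1 lies well beyond the usual scatter of repeated measurements, so compound 2 is the stronger of the two measured compounds on the shared core.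

Compound 3 `CC(=O)N1CCC(CN2CCC(CNC(=O)c3cccc4[nH]c(C(C)C)nc34)CC2)CC1` is not yet measured. It differs from compound 2 in one place: 1-acetylpiperidin-4-yl in place of (4-(methylsulfonyl)piperazin-1-yl)methyl on a saturated chain carbon bound to an amine nitrogen in a ring. The saturated chain carbon bound to the ring amine nitrogen, the amide and the shared core stay as in compound 2. Within the data shown here, no measured pair tracks this exchange, so there is no recorded step to lean on; the expectation rests on compound 2 alone, which gives 0.794 nM.

The step from compound 2 to compound 3 is expected to be a modest weakening, on the order of a 3.1-fold higher number from compound 2 to compound 3 (0.50 log units; beyond the scatter), since the ring amine of the chain is kept while the sulfonylpiperazine arm is exchanged. Compound 3 is therefore estimated at 2.5 nM in this assay, with a likely range from 0.5 nM to 15 nM.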

Compound 3, inhibition constant: 1 nM
Compound 3: middle estimate off by 2.5-fold (0.40 log units), on the high side; low and high end bracket the measured number.
By their numbers in this assay, from the lowest: compounds 2 and 3 (each within the scatter of the next); then compound 1.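

On the saturated chain carbon bound to an amine nitrogen in a ring, 1-acetylpiperidin-4-yl in place of (4-(methylsulfonyl)piperazin-1-yl)methyl gives a 1.3-fold higher number from compound 2 to compound 3 (0.10 log units; within the scatter) in this assay, so this exchange leaves the two compounds indistinguishable. The methylsulfonyl group and the piperazine ring are therefore not needed at this place for a value of this order: compound 3 reaches 1 nM with an entering group that has fewer heavy atoms, fewer hydrogen-bond acceptors and one ring hetero atom fewer. No measurement on hand accounts for this result, and no cause can be assigned to it.

Still open, as far as these compounds go, is what the acetyl group contributes, and whether a free piperidine amine, a methyl group or a carboxylic acid in place of 1-acetylpiperidin-4-yl would hold a value of this order in this assay. Compound 1 differs from compound 2 in more than one place, so the distance between them cannot yet be assigned to any single part of the structure.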